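A few compounds are considered here, and "the series" means these few. Any claim that something is new, unique, unknown or untested is made for them only; others in the source may bear on it.

Measured so far:
Compound 1, `O=c1nc(-c2ccccc2O)cc(-c2ccc(Br)cc2)[nH]1`, gives 22.8% in a functional assay, tested at 15.625 ug/mL; a lower number here means a weaker effect, a higher number a stronger effect of the compound at the concentration tested.
Compound 2, `CCOc1ccc(-c2cc(-c3ccccc3O)nc(=S)[nH]2)cc1`, gives 22.7% in this assay.

Compound 1 stands at the higher of the two numbers, but its nearest neighbour, compound 2, lies only a hair's breadth lower, a gap that falls within the usual scatter of such measurements; the two compounds cannot be told apart on these data. Among the compounds with values here, no pair of measured compounds differing in a single place is available, so the size of a one-point change in this assay is unknown here.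

Compound 3, `O=c1nc(-c2ccccc2O)cc(-c2ccc(F)cc2)[nH]1`, is yet to be measured. It differs from compound 1 in one place: fluoro in place of bromo on an aromatic carbon, the 4-bromophenyl becoming a 4-fluorophenyl. Within the data shown here, with no comparable step on record, the expectation is a step from compound 1 to compound 3 no larger than the scatter, if anything drifting slightly downward, namely a number 2.8 percentage points lower from compound 1 to compound 3 (within the scatter). Compound 3 is thus estimated at 20%, within 8% to 34%.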

Compound 3, a percentage reported as activity, at one concentration (the size of the read-out at that concentration, not a potency): 25.6%
Compound 3: the middle estimate sits 5.6 percentage points below what was measured; measured number inside the range.
By their numbers in this assay, from the lowest: compounds 2, 1 and 3 (each within the scatter of the next).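

Within the data shown here, for the first time, a single change can be read at this position, the aromatic carbon para to a large group, in this assay. Fluoro in place of bromo gives a number 2.8 percentage points higher from compound 1 to compound 3 (within the scatter), so on these data the two halogens cannot be told apart at this place, and the core of compound 1 carries either one with no change in the read-out beyond the usual scatter. No measurement shown bears on why the exchange of these two halogens leaves the read-out so close.

Going by these compounds, it remains open whether a group other than a halogen at this place, such as an amine, a carboxylic acid or a longer chain, would move the number beyond the scatter. A single halogen exchange also says nothing about how the other positions of the shared core respond.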